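This account rests on a few compounds, and the source may have more. Where it says the series, first, only, none or still open, it means among the compounds named here.

Compound 1 `Nc1ccccc1NC(=O)c1ccc(COc2ccc(Br)cc2)cc1`: > 32000 nM
Compound 2 `O=C(/C=C/c1ccc(CN2CCc3ccccc32)cc1)NO`: "not determined" (no result reported)
Compound 3 `Nc1ccccc1NC(=O)/C=C/c1ccc(COc2ccccc2)cc1`: > 32000 nM

In a functional assay on MGC-803 cells (Homo sapiens) for antiproliferative activity, read by CCK-8 assay, with a stated time of 72 h (on this read-out lower numbers stand for stronger inhibition and higher numbers for weaker inhibition), compound 1 gives > 32000 nM, which is a limit of the assay and not a number. Compound 3 gives > 32000 nM, again a limit. Compound 2 has no result to compare, so compound 1 stands at the limit of > 32000 nM in this assay, at which 2 of the 3 values shown sit.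

The next compound to be tested is compound 4 `COc1ccc(OCc2ccc(C(=O)Nc3ccccc3N)cc2)cc1`. It keeps the core of compound 1 and changes one group: methoxy in place of bromo on an aromatic carbon, para to a large group (methoxy in place of bromo on an aromatic carbon). The 4-bromophenyl thus becomes a 4-methoxyphenyl.

Going by the values given here, no measured pair shows what a change like this does, so there is little to go on. Given that compound 1 gives > 32000 nM, a limit, no step beyond the usual scatter is expected in this assay, and no direction is favoured. The expected change, a number no higher from compound 1 to compound 4 (the limit leaves the size open), is therefore small. For compound 4 the estimated value is 32000 nM, with an expected range from 12000 nM to 60000 nM.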

Compound 4, half-maximal inhibitory concentration: 3480 nM
The estimate for compound 4 lay 9.2-fold (0.96 log units) above the measured number; measured number below the stated range.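

Until now, the only numbers in this assay were limits, so the compounds shown gave no sign of how far a change could move the read-out. Compound 1 gives > 32000 nM, which is a limit of the assay and not a number. Replacing the 4-bromophenyl with a 4-methoxyphenyl gives an at least 9.1-fold lower number from compound 1 to compound 4 (0.96 log units; beyond the scatter), so the group at this position, para to a large group, matters in this assay, although the full size of the step stays unknown: the limit of > 32000 nM in this assay, at which 2 of the 4 values shown sit.

A single swap cannot separate what the loss of bromo contributes from what the arrival of methoxy contributes. Going by these compounds, it also remains open whether a hydroxyl, an amine or a longer chain such as ethoxy at this position would lower the number further or raise it again.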